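The source may report more compounds than this note shows. Statements on the series, on what has been measured and on what is new or still open speak of the compounds shown alone.

Compound 1 `Cc1cc(Nc2ccc(C(=O)/C=C/c3ccccc3)cc2)n2nc(SCc3nc4ccccc4[nH]3)nc2n1` stands as the weaker of the two compounds measured in a functional assay on SW-620 cells (Homo sapiens) for cytotoxicity, read by MTT assay, with stated times of 4 h and 72 h, tested at 2 uM; a lower number here means a stronger inhibitor, a higher number a weaker inhibitor: compound 1 gives 130 nM, while compound 2 `Cc1cc(Nc2ccc(C(=O)/C=C/c3ccc4ccccc4c3)cc2)n2nc(SCc3nc4ccccc4[nH]3)nc2n1` gives 5 nM, a step of a 26-fold lower number from compound 1 to compound 2 (1.41 log units; beyond the scatter). Compound 3 `Cc1cc(Nc2ccc(C(=O)/C=C/c3ccc(F)cc3)cc2)n2nc(SCc3nc4ccccc4[nH]3)nc2n1` differs from compound 1 by fluoro in place of hydrogen on an aromatic carbon. Within the data shown here, no measured step bears directly on this change; the single known step exchanges the whole aromatic ring rather than adding a substituent to it, so it offers little guidance for a lone fluoro. A step within the scatter is therefore expected, a 1.3-fold lower number from compound 1 to compound 3 (0.11 log units; within the scatter). For compound 3 the estimate in this assay is 100 nM, with a range of 40 nM to 300 nM.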

Compound 3, half-maximal inhibitory concentration: 85 nM
Estimate against measurement, compound 3: 1.2-fold (0.07 log units) above; measured number inside the range.
By their numbers in this assay, from the lowest: compound 2; then compounds 3 and 1 (each within the scatter of the next).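

In this assay, fluoro in place of hydrogen on this aromatic carbon, para to a large group, leaves the number within the scatter: a 1.5-fold lower number from compound 1 to compound 3 (0.18 log units; within the scatter). Exchanging the 4-fluorophenyl group with naphthalen-2-yl, by contrast, gives a large step: a 17-fold higher number from compound 2 to compound 3 (1.23 log units; beyond the scatter). So far, a lone fluoro on this ring does not reproduce the large step seen with naphthalen-2-yl, and nothing on hand explains either step. Open, going by these compounds, is whether methoxy or dimethylamino on the same aromatic carbon also stays within the scatter. Also open, on these data alone, is whether naphthalen-1-yl matches naphthalen-2-yl.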